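Notes on the hydroxamate series: methoxy to chloro step

The source may hold more compounds than are shown below. What is called first, only, known or untested is meant among the compounds shown, and "the series" means these compounds.

In a functional assay on HL-60 cells (Homo sapiens) for antiproliferative activity, tested at 100 uM (on this read-out lower numbers stand for a weaker effect and higher numbers for a stronger effect at the one concentration tested), compound 1 `COC(=O)c1ccc(OC)c(S(=O)(=O)Nc2ccc3c(c2)cc(C)c(=O)n3C)c1` gives 66%, compound 2 `COc1ccc(C(=O)NOCc2ccc(OC(C)=O)cc2)cc1S(=O)(=O)Nc1ccc2c(c1)cc(C)c(=O)n2C` gives 95%, and compound 3 `COc1ccc(C(=O)NO)cc1S(=O)(=O)Nc1ccc2c(c1)cc(C)c(=O)n2C` gives 39%, so compound 3 stands lowest of the three: a number 27 percentage points lower from compound 1 to compound 3 (beyond the scatter) and a number 56 percentage points lower from compound 2 to compound 3 (beyond the scatter). Compound 4 `Cc1cc2cc(NS(=O)(=O)c3cc(C(=O)NO)ccc3Cl)ccc2n(C)c1=O` differs from compound 3 in one place: chloro in place of methoxy on an aromatic carbon. Both measured steps alter the group on the carbonyl carbon or on its oxygen, not the aromatic carbon changed here, so neither bears directly on this step. Among the compounds with values here, no measured pair compares chloro against methoxy at that position, so the expected step of a number 1 percentage points higher from compound 3 to compound 4 (within the scatter) in this assay is taken as none beyond the scatter. For compound 4 the estimate is 40%, with a range from 15% to 65%.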

Compound 4, a percentage reported as inhibition, at one concentration (the size of the read-out at that concentration, not a potency): 33%
For compound 4 the middle estimate is 7 percentage points above the measured one; measured number inside the range.
By their numbers in this assay, from the lowest: compounds 4 and 3 (each within the scatter of the next); then compound 1; then compound 2.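

Within the data shown here, at the aromatic carbon para to a hydroxycarbamoyl group, the earlier steps gave no reading, as they changed only the group on the carbonyl carbon or on its oxygen. In this assay this first step at that carbon reads a number 6 percentage points lower from compound 3 to compound 4 (within the scatter) and so does not separate chloro from methoxy in the hydroxamate series. Nothing measured here offers an explanation for this result.

On these data alone, whether an amine or a longer alkoxy chain at this carbon would stay within the scatter remains open. So does whether chloro and methoxy also match when the 4-acetoxybenzyl group sits on the oxygen.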